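The compounds below may be only part of what the source reports. "The series", "measured", "known", "first", "only" and "open" are said of these compounds alone.

Series notes, read in a functional assay on HEK293 cells for agonist activity at G-protein coupled receptor 39 (Homo sapiens), read by scintillation proximity assay and inositol phosphate accumulation, with a stated time of 75 min; on this read-out higher numbers stand for an effect only at larger amounts of compound and lower numbers for an effect already at smaller amounts.

- compound 1 `Cc1nn(-c2ncnc3nc[nH]c23)c2c1C(c1ccc(OC(C)C)cc1)CC(=O)N2` gives 2700 nM
- compound 2 `Cc1nn(-c2ncnc3nc[nH]c23)c2c1C(OC(=O)c1ccc(F)cc1)CC(=O)N2` gives 245 nM
- compound 3 `Cc1nn(-c2ncnc3nc[nH]c23)c2c1C(C(=O)NCc1ccc(F)cc1)CC(=O)N2` gives 1220 nM

Compound 1 stands highest of the three numbers in this assay; compound 3 sits nearest to it, below, and compound 2 furthest below it. For the measured compounds named here, the one single-place step measured from compound 1 is an 11-fold lower number from compound 1 to compound 2 (1.04 log units; beyond the scatter), a large move to a lower number. Going by the values given here, compound 3 is not a single-place step from compound 1; its value and that of compound 1 show only that compound 3 also gives the lower number of the two.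

Compound 4 `Cc1nn(-c2ncnc3nc[nH]c23)c2c1C(OCc1ccc(Cl)cc1Cl)CC(=O)N2` is not yet measured in this assay. It differs from compound 1 by (2,4-dichlorobenzyl)oxy in place of 4-isopropoxyphenyl on a saturated ring carbon. As in compound 2, the entering group contains an oxygen and a six-membered aromatic ring of carbon only, and the group leaving is the same 4-isopropoxyphenyl at the same saturated ring carbon, so the step to compound 2 is the one that bears on it, and it was large. Among the compounds with values here, only one such step is known, and the new group is a benzyl ether rather than the ester of compound 2, so the full size of that step is not assumed. A lower number is expected for compound 4, the expected step being a 4.9-fold lower number from compound 1 to compound 4 (0.69 log units; beyond the scatter). Compound 4 is therefore estimated at 550 nM, with a range from 150 nM to 2000 nM.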

Compound 4, half-maximal effective concentration: 243 nM
Beside the measured number, compound 4's estimate is 2.3-fold (0.35 log units) above it; low and high end bracket the measured number.
By their numbers in this assay, from the lowest: compounds 4 and 2 (each within the scatter of the next); then compound 3; then compound 1.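

At this saturated ring carbon, in this assay, a second entering group with an oxygen gives a large move: (2,4-dichlorobenzyl)oxy in place of 4-isopropoxyphenyl gives an 11-fold lower number from compound 1 to compound 4 (1.05 log units; beyond the scatter), so a step of this size is no longer tied to the ester of compound 2. On the oxygen itself, 2,4-dichlorobenzyl in place of (4-fluorophenyl)carbonyl gives a 1.0-fold lower number from compound 2 to compound 4 (0.00 log units; within the scatter), within the scatter, so the ether and the ester cannot be told apart in this read-out, even though one has a carbonyl and the other a benzyl carbon and two chlorines. The data at hand offer no measurement that explains either step.

The compounds shown do not separate the part played by the oxygen from that of the aromatic ring, a question that a plain hydroxyl or a methoxy at this carbon, or an amine in place of the oxygen, would address. As far as these compounds go, the part played by the ring substituents also stays open, and the unsubstituted benzyl ether would bear on the two chlorines.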